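Swapping acetamido for methanesulfonamido on a nitrofuran amide

This account rests on a few compounds, and the source may have more. Where it says the series, first, only, none or still open, it means among the compounds named here.

Among the measured compounds shown here, compound 1 `CC(=O)Nc1cccc(-c2csc(NC(=O)c3ccc([N+](=O)[O-])o3)n2)c1` is the only compound here with a number: in an ADME assay on Vero cells (Chlorocebus sabaeus) for cytotoxicity, read by MTT assay, with a stated time of 72 h (a lower number here means a stronger inhibitor, a higher number a weaker inhibitor), compound 1 gives 57600 nM, a weak effect on these cells. Compound 2 `O=C(Nc1cccc(-c2csc(NC(=O)c3ccc([N+](=O)[O-])o3)n2)c1)c1cccc(C(F)(F)F)c1` was tested, but in this assay compound 2 gives "not determined" (no result reported), so nothing can be said of it. Compound 3 `CS(=O)(=O)Nc1cccc(-c2csc(NC(=O)c3ccc([N+](=O)[O-])o3)n2)c1` differs from compound 1 by one change (methylsulfonyl in place of acetyl on a nitrogen on an aromatic ring), acetamido becoming methanesulfonamido. For the measured compounds named here, with no step between measured compounds to guide the size, the expected step from compound 1 to compound 3 in this assay is small, within scatter a 1.0-fold higher number from compound 1 to compound 3 (0.02 log units; within the scatter). Compound 3 is therefore estimated at 60000 nM, with a likely range from 25000 nM to 150000 nM.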

Compound 3, half-maximal inhibitory concentration: < 2820 nM
Compound 3 gave a limit, no number; the forecaster's own chance of this, stated with the estimate: 30%; middle value at least 21-fold (1.32 log units) away from the limit.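

In this assay, the group on this nitrogen turns out to matter a great deal: methylsulfonyl in place of acetyl gives an at least 20-fold lower number from compound 1 to compound 3 (1.31 log units; beyond the scatter) on the otherwise shared core. As far as these compounds go, compound 3 gives < 2820 nM, which is a limit of the assay and not a number, so the full size of the step stays unknown: the limit of < 2820 nM in this assay, at which 1 of the 3 values shown sits.

From the compounds shown here alone, whether a free amine or a longer chain, such as ethylsulfonyl, on this nitrogen would read like the acetyl or like the methylsulfonyl remains open.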